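Enlarging the Aromatic Arm on a Shared Core

The compounds below may be only part of what the source reports. "The series", "measured", "known", "first", "only" and "open" are said of these compounds alone.

Compound 2 `CCOC(=O)C1=C(Nc2ccccc2)S/C(=C\c2ccc[nH]2)C1=O` and compound 1 `CCOC(=O)C1=C(Nc2ccccc2)S/C(=C\c2ccc(OC)cc2)C1=O` share one core and differ only in the aromatic group on a double-bonded chain carbon bound to a double-bonded ring carbon. In a functional assay on A549 cells (Homo sapiens) for inhibition, read by MTT assay, with a stated time of 72 h, tested at 10 uM (on this read-out higher numbers stand for more inhibition at the one concentration tested (going by the name of the read-out) and lower numbers for less inhibition), compound 1 gives 17.5%, and compound 2 gives 23.5%. On these two numbers compound 2 stands as the higher, yet the step of a number 6 percentage points higher from compound 1 to compound 2 (within the scatter) lies within the scatter, so the two cannot be told apart. Compound 3 `CCOC(=O)C1=C(Nc2ccccc2)S/C(=C\c2cc3ccncc3[nH]2)C1=O` is not yet measured. It differs from compound 2 by a group of 9 heavy atoms (7 carbon, 2 nitrogen; one five-membered aromatic ring with 1 hetero atom, one six-membered aromatic ring with 1 hetero atom) in place of a group of 5 heavy atoms (4 carbon, 1 nitrogen; one five-membered aromatic ring with 1 hetero atom), on a double-bonded chain carbon bound to a double-bonded ring carbon. Among the measured compounds shown here, the only measured step that bears on this, a number 6 percentage points higher from compound 1 to compound 2 (within the scatter), also exchanged the aromatic group at this place and barely moved the read-out, so no step beyond the scatter in this assay is expected, although a single comparison is a thin basis. For compound 3 the expected value is 26%, with a range from 10% to 45%. That estimate amounts to a step of a number 2.5 percentage points higher from compound 2 to compound 3 (within the scatter).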

Compound 3, a percentage reported as inhibition, at one concentration (the size of the read-out at that concentration, not a potency): 17.1%
Compound 3: the middle estimate sits 8.9 percentage points above what was measured; the range from low to high includes it.
By their numbers in this assay, from the lowest: compounds 3, 1 and 2 (each within the scatter of the next).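

Adding a six-membered aromatic ring to the five-membered one at this place gives no readable change in this assay (a number 6.4 percentage points lower from compound 2 to compound 3 (within the scatter)), and exchanging the 4-methoxyphenyl group for the same larger group gives none either (a number 0.4 percentage points lower from compound 1 to compound 3 (within the scatter)). Across these three compounds, then, the aromatic group on the double-bonded chain carbon can grow from 5 to 9 heavy atoms, and can carry a second ring nitrogen, without the read-out separating them. Nothing available explains why these numbers stay together.

The compounds shown carry only aromatic groups at this place, so what an amine, a carboxylic acid or a longer chain would do there stays open. From the compounds shown here alone, whether the ethyl ester or the phenyl on the amine matters also stays open, since both are the same throughout.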